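Three ureas and thioureas, one thiourea still unmeasured

The compounds below may be only part of what the source reports. "The series", "measured", "known", "first", "only" and "open" are said of these compounds alone.

Measured so far:
compound 1 `CC1(C)CC(NC(=O)NCc2ccccc2)c2cc(Br)ccc2O1` gives 27000 nM in a functional assay on U-373MG ATCC cells (Homo sapiens) for inhibition, read by MTT assay, with a stated time of 72 h; on this read-out higher numbers stand for weaker inhibition and lower numbers for stronger inhibition
compound 2 `CC1(C)CC(NC(=S)NCc2ccccc2)c2cc(Br)ccc2O1` gives 29000 nM in this assay
compound 3 `CC1(C)CC(NC(=O)Nc2ccc(Cl)cc2)c2cc(Br)ccc2O1` gives 25000 nM in this assay

All three numbers sit close together. Within the data shown here, the one step that can be counted is a 1.1-fold lower number from compound 1 to compound 3 (0.03 log units; within the scatter), the change being (4-chlorophenyl in place of benzyl on an amide-type nitrogen). Compound 2 and compound 1 differ in more than one place, so the difference between the two cores is not broken down here; their two values differ only within the usual scatter, and the same holds for compound 2 against compound 3.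

Compound 4 `CC1(C)CC(NC(=S)Nc2ccc(Cl)cc2)c2cc(Br)ccc2O1` has not yet been measured in this assay. It is related to compound 2 by 4-chlorophenyl in place of benzyl on an amide-type nitrogen. This is the same kind of change as from compound 1 to compound 3, not the same one: there the nitrogen's other neighbour is a carbonyl carbon, here it is a thiocarbonyl carbon.

Among the measured compounds shown here, for compound 4 the step from compound 2 is expected to be about a 1.1-fold lower number from compound 2 to compound 4 (0.03 log units; within the scatter), resting on the single earlier instance, a 1.1-fold lower number from compound 1 to compound 3 (0.03 log units; within the scatter), which stayed within the scatter. Compound 4 is therefore estimated at 27000 nM, with a plausible range from 13000 nM to 56000 nM. Compound 4 is thus expected to sit near compound 2 and the two ureas, with no sign in these data of a larger movement.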

Compound 4, half-maximal inhibitory concentration: 7000 nM
For compound 4 the middle estimate is 3.9-fold (0.59 log units) above the measured one, and the stated range ends above it.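

In this assay, 4-chlorophenyl in place of benzyl on an amide-type nitrogen whose other neighbour is a thiocarbonyl carbon gives a 4.1-fold lower number from compound 2 to compound 4 (0.62 log units; beyond the scatter). The change therefore does not carry over with a single size between the carbonyl and thiocarbonyl compounds, so a step read on one of these cores is a poor guide to the same step on the other: the same change on two cores in this assay, a 1.1-fold lower number (0.03 log units; within the scatter) from compound 1 to compound 3 and a 4.1-fold lower number (0.62 log units; beyond the scatter) from compound 2 to compound 4, 3.8-fold (0.58 log units) apart, beyond the scatter of two such steps

This rests on one pair of compounds per core, so it shows that the size of the step depended on the core here, but not what sets that difference, nor whether it would recur for any other replacement on this nitrogen.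

As far as these compounds go, the exchange of benzyl for 4-chlorophenyl alters the link to the ring and adds the chlorine in one move, so it remains open whether the lower number of compound 4 goes with the phenyl attachment or with the chlorine. A plain phenyl, a 4-chlorobenzyl or a 4-methoxyphenyl group on the same nitrogen, each paired on both the carbonyl and the thiocarbonyl core, would be needed to separate these and to test whether the dependence on the core holds beyond these four compounds.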